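The compounds below may be only part of what the source reports. "The series", "measured", "known", "first", "only" and "open" are said of these compounds alone.

Measured compounds:
compound 1 `C#CCSc1nnc(CC)n1N1C(=O)c2ccccc2C1=O` gives > 200000 nM in a functional assay on MKN-45 cells (Homo sapiens) for cytotoxicity, read by MTT assay, with a stated time of 48 h (on this read-out higher numbers stand for weaker inhibition and lower numbers for stronger inhibition), a limit of the assay.
compound 2 `C#CCSc1nnc(CCC)n1N1C(=O)c2ccccc2C1=O` gives > 200000 nM in this assay, again a limit.
compound 3 `C#CCSc1nnc(-c2cc(OC)c(OC)c(OC)c2)n1N1C(=O)c2ccccc2C1=O` gives > 200000 nM in this assay, likewise a limit.

Compound 3 thus stands at the limit, with no number of its own; the limit of > 200000 nM in this assay, at which 3 of the 3 values shown sit, describes the whole measured set. Going by the values given here, the one measured step that differs in a single place, a step that the two limits leave unreadable from compound 1 to compound 2, is unreadable between two limits and bears on the present change only as a sign that the series so far shows no inhibition.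

Compound 4 `COc1cc(-c2nnc(SCC(=O)c3ccccc3C)n2N2C(=O)c3ccccc3C2=O)cc(OC)c1OC` carries (2-methylphenyl)carbonyl in place of ethynyl on a saturated chain carbon bound to a sulfur. Among the compounds with values here, no measured step covers this change, so the expectation rests on the limits alone; a step of about an at least 1.3-fold lower number from compound 3 to compound 4 (0.12 log units; that floor lies within the scatter) is estimated, towards no read beyond the scatter. Compound 4 is expected at 150000 nM, range 30000 nM to 300000 nM, most likely again a limit.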

Compound 4, half-maximal inhibitory concentration: > 200000 nM
Compound 4 gave a limit, no number; the forecaster's own chance of this, stated with the estimate: 60%; middle value at least 1.3-fold (0.12 log units) away from the limit.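

No step can be read from compound 3 to compound 4, as both values are limits, as is every value in the series: the limit of > 200000 nM in this assay, at which 4 of the 4 values shown sit.

The compounds shown leave open whether any group on the shared core gives a readable number in this assay.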